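Notes on purine ribosides: the sulfur substituent of compound 3

A few compounds are considered here, and "the series" means these few. Any claim that something is new, unique, unknown or untested is made for them only; others in the source may bear on it.

Measured so far:
compound 1 `OC[C@H]1O[C@@H](n2cnc3c(OCc4ccccc4)ncnc32)[C@H](O)[C@@H]1O` gives 2090 nM
compound 2 `CCSc1ncnc2c1ncn2[C@@H]1O[C@H](CO)[C@@H](O)[C@H]1O` gives 57500 nM
compound 3 `CCCCSc1nc(N)nc2c1ncn2[C@@H]1O[C@H](CO)[C@@H](O)[C@H]1O` gives 12000 nM

In an assay on isolated protein for binding affinity to Equilibrative nucleoside transporter 1 (Homo sapiens) (on this read-out lower numbers stand for stronger inhibition and higher numbers for weaker inhibition), compound 3 stands second highest of the three numbers: compound 2 gives a higher number and compound 1 a lower one. Compound 4 `Nc1nc(SI)c2ncn([C@@H]3O[C@H](CO)[C@@H](O)[C@H]3O)c2n1` differs from compound 3 by iodo in place of butyl on a sulfur. Within the data shown here, no measured step touches the sulfur substituent itself. Among the measured compounds shown here, the only single-place step known, a 28-fold higher number from compound 1 to compound 2 (1.44 log units; beyond the scatter), swaps benzyloxy for the smaller ethylsulfanyl group and weakens binding strongly. Compound 3 with butyl and compound 2 with ethyl differ in two places, so their gap is merely noted. Going from butyl to the single-atom iodo is therefore expected to raise the number, a moderate step of a 2.9-fold higher number from compound 3 to compound 4 (0.46 log units; beyond the scatter). Compound 4 is expected at 35000 nM, range 10000 nM to 120000 nM.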

Compound 4, half-maximal inhibitory concentration: 81300 nM
The estimate for compound 4 lay 2.3-fold (0.37 log units) below the measured number; the range from low to high includes it.
By their numbers in this assay, from the lowest: compound 1; then compound 3; then compounds 2 and 4 (each within the scatter of the next).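

This sulfur now has a single-place step of its own: iodo in place of butyl on a sulfur gives a 6.8-fold higher number from compound 3 to compound 4 (0.83 log units; beyond the scatter) in this assay and places the change beyond the scatter. The number therefore responds to what sits on this sulfur, with all else in the core of compound 3 held constant, and butyl gives the lower number of the two groups. Nothing measured here accounts for the step.

As far as these compounds go, with only butyl and iodo compared on this sulfur, it remains open how a hexyl chain or a benzyl group would read. A carboxylic acid at the end of the butyl chain is equally untested in these compounds.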